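The source may report more compounds than this note shows. Statements on the series, on what has been measured and on what is new or still open speak of the compounds shown alone.

In a functional assay on A549 cells (Homo sapiens) for antiproliferative activity, read by XTT assay, with a stated time of 72 h (on this read-out higher numbers stand for weaker inhibition and lower numbers for stronger inhibition), compound 1 `COc1ccc(-c2cc3ccccc3nc2/C=C/C(=O)c2ccc(F)cc2)cc1` gives 8320 nM. Compound 2 `COc1ccc(-c2cc3ccccc3nc2/C=C/C(=O)c2ccc(O)cc2)cc1` gives 7440 nM and compound 3 `COc1ccc(-c2cc3ccccc3nc2/C=C/C(=O)c2ccc(N)cc2)cc1` gives 7530 nM, so compound 1 stands level with both, within the scatter. Compound 4 `COc1ccc(-c2cc3ccccc3nc2/C=C/C(=O)c2ccco2)cc1` has not yet been measured. Its difference from compound 1 is furan-2-yl in place of 4-fluorophenyl on a carbonyl carbon. The measured steps that bear on this are a 1.1-fold lower number from compound 1 to compound 2 (0.05 log units; within the scatter) and a 1.1-fold lower number from compound 1 to compound 3 (0.04 log units; within the scatter), and alongside them a 1.0-fold higher number from compound 2 to compound 3 (0.01 log units; within the scatter). All three are small and lie within the scatter. They only exchange fluoro for hydroxy or amino on an aromatic carbon, while compound 4 loses the whole 4-fluorophenyl, so none of them measures this change directly. No step beyond the scatter is therefore expected, although the uncertainty is wide. The expected step is a 1.0-fold lower number from compound 1 to compound 4 (0.02 log units; within the scatter). For compound 4 the estimated value is 8000 nM, with an expected range from 3500 nM to 20000 nM.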

Compound 4, half-maximal inhibitory concentration: 6130 nM
For compound 4 the middle estimate is 1.3-fold (0.12 log units) above the measured one, within the range that was stated.
By their numbers in this assay, from the lowest: compounds 4, 2, 3 and 1 (each within the scatter of the next).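

In this assay the change reaches further than the earlier exchanges on the aromatic carbon, since the whole 4-fluorophenyl gives way to furan-2-yl, a five-membered aromatic ring with 1 hetero atom. All three routes to compound 4 stay within the scatter (a 1.4-fold lower number from compound 1 to compound 4 (0.13 log units; within the scatter); a 1.2-fold lower number from compound 3 to compound 4 (0.09 log units; within the scatter); a 1.2-fold lower number from compound 2 to compound 4 (0.08 log units; within the scatter)), so on a carbonyl carbon in this series the six-membered carbon ring is not required to keep the number level with the others. Nothing measured here accounts for this level result.

As far as these compounds go, what a methyl group, a longer alkyl chain or a saturated ring such as piperidine would give on this carbonyl carbon stays open. So does the effect of a change elsewhere in the molecule, such as a hydroxy group in place of the methoxy.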